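The source may hold more compounds than are shown below. What is called first, only, known or untested is meant among the compounds shown, and "the series" means these compounds.

Measured in a functional assay on A-431 cells (Homo sapiens) for antiproliferative activity, read by MTT assay, with a stated time of 72 h; on this read-out lower numbers stand for stronger inhibition and higher numbers for weaker inhibition:
Compound 1 `O=C(Nc1cccc(CN2CCCC2)c1)Nc1ccc2ncnc(Nc3cccc(C(F)(F)F)c3)c2c1` gives 1230 nM.
Compound 2 `O=C(Nc1ccccc1)Nc1ccc2ncnc(Nc3cccc(C(F)(F)F)c3)c2c1` gives only a limit of the assay, > 10000 nM.
Compound 3 `COc1ccc(NC(=O)Nc2ccc3ncnc(Nc4cccc(C(F)(F)F)c4)c3c2)cc1` gives 4950 nM.

Compound 3 holds the highest of the two numbers in this assay; its nearest neighbour is compound 1, separated by a 4.0-fold higher number from compound 1 to compound 3 (0.60 log units; beyond the scatter). Compound 2 sits at the limit of > 10000 nM in this assay, at which 1 of the 3 values shown sits, and so gives no number to rank.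

Compound 4 `CCN(CC)c1ccc(NC(=O)Nc2ccc3ncnc(Nc4cccc(C(F)(F)F)c4)c3c2)cc1` differs from compound 3 by diethylamino in place of methoxy on an aromatic carbon. Among the compounds with values here, no measured step makes this exact change. Within the data shown here, two steps bear on it. an at least 2.0-fold lower number from compound 2 to compound 3 (0.30 log units; that floor lies within the scatter) shows that a small group entering on an aromatic carbon of this phenyl ring moves the number, if at all, by an amount whose floor lies within the scatter. a 4.0-fold higher number from compound 1 to compound 3 (0.60 log units; beyond the scatter) shows that exchanging one substituted phenyl for another on the amide-type nitrogen can give a modest step. In this assay a step of at most modest size is therefore expected for compound 4, with no firm direction, leaning towards a lower number, as a 1.7-fold lower number from compound 3 to compound 4 (0.22 log units; within the scatter). Compound 4 is estimated at 3000 nM, in the range 900 nM to 10000 nM.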

Compound 4, half-maximal inhibitory concentration: 6460 nM
Estimate against measurement, compound 4: 2.2-fold (0.33 log units) below; low and high end bracket the measured number.
By their numbers in this assay, from the lowest: compound 1; then compounds 3 and 4 (each within the scatter of the next). At a limit, above all of these: compound 2.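

In this assay, diethylamino in place of methoxy on this ring, para to a large group, gives a 1.3-fold higher number from compound 3 to compound 4 (0.12 log units; within the scatter), so the larger group, with 5 heavy atoms against 2, leaves compound 3 and compound 4 indistinguishable. Exchanging the whole 3-((pyrrolidin-1-yl)methyl)phenyl for 4-(diethylamino)phenyl gives a 5.3-fold higher number from compound 1 to compound 4 (0.72 log units; beyond the scatter), so a tertiary amine on this ring does not by itself match compound 1 here, although this step changes both the amine-bearing group and its place on the ring. The comparison with hydrogen reads an at least 1.5-fold lower number from compound 2 to compound 4 (0.18 log units; that floor lies within the scatter), but it starts from a limit and not a number, so what diethylamino adds over hydrogen has no measured size: the limit of > 10000 nM in this assay, at which 1 of the 4 values shown sits.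

On these data alone, it remains open whether 4-((pyrrolidin-1-yl)methyl)phenyl would read with compound 1 or with compound 4 in this assay, which would separate the identity of the group from its place on the ring. Also open, as far as these compounds go, is how a morpholin-4-ylmethyl group or a carboxylic acid on this ring would read.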